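A few compounds are considered here, and "the series" means these few. Any claim that something is new, unique, unknown or untested is made for them only; others in the source may bear on it.

Working notes on the aryl carbamate series.

Three compounds carry measured numbers in an assay (strain Wistar) for inhibition of Fatty-acid amide hydrolase 1 (Rattus norvegicus), read by scintillation counting; a higher number here means a weaker inhibitor, a lower number a stronger inhibitor. Compound 2 `O=C(NC1CCCC1)Oc1cccc(C2=NCCO2)c1` gives 13 nM. Compound 3 `O=C(NC1CCCCC1)Oc1cccc(C2=NCCO2)c1` gives 1.2 nM. Compound 1 `CCCNC(=O)Oc1cccc(-c2nc3ncccc3o2)c1` gives 680 nM. Compound 2 therefore stands second highest of the three: nearest is compound 3, furthest is compound 1, whose number lies well above it.

For the measured compounds named here, the only step between two compounds that differ in one place is an 11-fold lower number from compound 2 to compound 3 (1.03 log units; beyond the scatter); it concerns the substituent on the amide-type nitrogen, not the ring on the aromatic carbon.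

Compound 4 `CC1(C)COC(c2cccc(OC(=O)NC3CCCC3)c2)=N1` differs from compound 2 in a group of 7 heavy atoms (5 carbon, 1 nitrogen, 1 oxygen; one five-membered non-aromatic ring with 2 hetero atoms) in place of a group of 5 heavy atoms (3 carbon, 1 nitrogen, 1 oxygen; one five-membered non-aromatic ring with 2 hetero atoms), on an aromatic carbon. Going by the values given here, no measured step touches this part of the molecule, and compound 1 differs from compound 2 in more than one place, so its value gives no clean read on the ring alone. The step from compound 2 to compound 3 does not bear on this change. With nothing directly comparable, the expected step is a 1.5-fold higher number from compound 2 to compound 4 (0.19 log units; within the scatter), modest and uncertain in direction. Compound 4 is estimated at 20 nM in this assay, within 5 nM to 80 nM.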

Compound 4, half-maximal inhibitory concentration: 65 nM
Estimate against measurement, compound 4: 3.3-fold (0.51 log units) below, within the range that was stated.
By their numbers in this assay, from the lowest: compound 3; then compound 2; then compound 4; then compound 1.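

In this assay, for the compounds shown here, the change on the aromatic carbon gives a 5.0-fold higher number from compound 2 to compound 4 (0.70 log units; beyond the scatter), so this position, which no earlier step touched, is not indifferent to the group it carries. The group that leaves and the group that enters share a five-membered non-aromatic ring with 2 hetero atoms, 1 double bond outside aromatic rings and the same hydrogen-bond donor and acceptor counts, so the pair separates on the extra carbon atoms, and here those go with a weaker inhibitor. No measurement at hand gives an explanation for this step.

A single step cannot show whether a lone methyl, a hydroxymethyl or a carboxylic acid on that ring would behave like the group in compound 4. Going by these compounds, it also remains open whether the same ring change would cost as much with cyclohexyl in place of cyclopentyl on the amide-type nitrogen.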